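The compounds below may be only part of what the source reports. "The series", "measured", "known", "first", "only" and "open" are said of these compounds alone.

Working notes on the sulfonyl-substituted urea series.

Three compounds have numbers in an assay on isolated protein for inhibition of Nicotinamide phosphoribosyltransferase (Homo sapiens), read by spectrophotometry, with stated times of 15 min and 30 min; on this read-out lower numbers stand for stronger inhibition and higher numbers for weaker inhibition. Compound 1, `O=C(NCc1cnccn1)Nc1ccc(S(=O)(=O)c2ccccc2)cc1`, carries a phenyl on the sulfonyl sulfur; in this assay compound 1 gives 1300 nM. Compound 2, `C[C@@H]1COC[C@@H](C)N1S(=O)(=O)c1ccc(NC(=O)NCc2cccnc2)cc1`, carries a dimethylmorpholine on the sulfonyl sulfur; compound 2 gives 52 nM. Compound 3, `O=C(NCc1cccnc1)Nc1ccc(S(=O)(=O)N2CC3(COC3)C2)cc1`, carries the spiro-fused oxetane-azetidine; compound 3 gives 103 nM. Compound 3 thus stands second highest of the three numbers; its nearest neighbour is compound 2 and its furthest is compound 1.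

Going by the values given here, the one step so far that changes the group on the sulfonyl sulfur between two amine-type substituents is a 2.0-fold higher number from compound 2 to compound 3 (0.30 log units; within the scatter), so swapping one saturated nitrogen-linked group for another has moved the number little. The step from compound 1 to compound 2 is much larger, but it replaces a carbon-linked phenyl, not a nitrogen-linked ring.

Compound 4, `N[C@H]1CC[C@H](NS(=O)(=O)c2ccc(NC(=O)NCc3cccnc3)cc2)CC1`, is to be measured. The change is a group of 8 heavy atoms (6 carbon, 2 nitrogen; one six-membered non-aromatic ring of carbon only) in place of a group of 7 heavy atoms (5 carbon, 1 nitrogen, 1 oxygen; 2 four-membered non-aromatic rings with 1 hetero atom each), on a sulfonyl sulfur. The new group keeps a nitrogen on the sulfonyl sulfur, as in compound 2 and compound 3, so the relevant precedent is the small step from compound 2 to compound 3 rather than the large step from compound 1. The step is therefore expected to be a 1.5-fold higher number from compound 3 to compound 4 (0.16 log units; within the scatter), with no strong direction beyond the scatter. Compound 4 is estimated at 150 nM, within a range of 50 nM to 500 nM.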

Compound 4, half-maximal inhibitory concentration: 4 nM
Compound 4: middle estimate off by 38-fold (1.57 log units), on the high side, outside the stated range (below it).
By their numbers in this assay, from the lowest: compound 4; then compounds 2 and 3 (each within the scatter of the next); then compound 1.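

In this assay the group on the sulfonyl sulfur can move the number much further than a 2.0-fold higher number from compound 2 to compound 3 (0.30 log units; within the scatter) suggested, as (4-aminocyclohexyl)amino gives a 26-fold lower number from compound 3 to compound 4 (1.41 log units; beyond the scatter) and also a 13-fold lower number from compound 2 to compound 4 (1.11 log units; beyond the scatter). Both new steps lie beyond the scatter, so keeping a nitrogen on the sulfonyl sulfur does not by itself hold the number in one place, and the three nitrogen-linked groups no longer behave as interchangeable. The entering group differs from both groups it replaces in several counted features at once, with 2 hydrogen-bond donors against 0 and a six-membered ring of carbon only, and nothing available gives a reason for the drop in the number.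

The compounds shown leave open which part of the (4-aminocyclohexyl)amino group carries the step: the free amine on the ring, the hydrogen on the nitrogen attached to sulfur, or the carbon-only ring. A plain cyclohexylamino group, or a hydroxyl or carboxylic acid in place of the amine, would separate these, and the other stereoisomer of the diaminocyclohexane would show whether the defined stereocentres matter.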